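A few compounds are considered here, and "the series" means these few. Any claim that something is new, unique, unknown or untested is made for them only; others in the source may bear on it.

Measured compounds:
compound 1, `Cn1c(=O)c2nc(-c3ccc(I)cc3)[nH]c2n(C)c1=O`, 1.3 nM in an assay for binding affinity to adenosine receptor A1 (Bos taurus); on this read-out higher numbers stand for weaker inhibition and lower numbers for stronger inhibition
compound 2, `CCOc1ccc(-c2nc3c(=O)n(C)c(=O)n(C)c3[nH]2)cc1`, 2 nM in this assay
compound 3, `Cn1c(=O)c2nc(-c3ccc(Br)cc3)[nH]c2n(C)c1=O`, 0.75 nM in this assay

Compound 3 holds the lowest number of the three in this assay. Its nearest neighbour is compound 1, where the step of a 1.7-fold lower number from compound 1 to compound 3 (0.24 log units; within the scatter) lies within the scatter, so the two cannot be ordered. Its furthest neighbour is compound 2, where the step of a 2.7-fold lower number from compound 2 to compound 3 (0.43 log units; beyond the scatter) lies beyond the scatter, a modest change.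

Compound 4, `Cn1c(=O)c2nc(-c3ccc(F)cc3)[nH]c2n(C)c1=O`, differs from compound 3 by fluoro in place of bromo on an aromatic carbon. The step that bears on this change is the halogen exchange from compound 1 to compound 3: a 1.7-fold lower number from compound 1 to compound 3 (0.24 log units; within the scatter), within the scatter. The step of a 1.5-fold higher number from compound 1 to compound 2 (0.19 log units; within the scatter) also stayed within the scatter, while a 2.7-fold lower number from compound 2 to compound 3 (0.43 log units; beyond the scatter) went modestly beyond it. Exchanging one halogen for another at this position has so far moved the number little. A further halogen exchange is therefore expected to give at most a small step, likely toward a higher number, a 3.3-fold higher number from compound 3 to compound 4 (0.52 log units; beyond the scatter). Compound 4 is expected to give about 2.5 nM in this assay, within 0.8 nM to 8 nM.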

Compound 4, half-maximal inhibitory concentration: 3.5 nM
Beside the measured number, compound 4's estimate is 1.4-fold (0.15 log units) below it, and the stated range covers the measured number.
By their numbers in this assay, from the lowest: compounds 3, 1, 2 and 4 (each within the scatter of the next, the first and the last beyond it).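

In this assay, for the compounds shown here, the fluoro group is the first halogen here to stand apart from another, as both a 4.7-fold higher number from compound 3 to compound 4 (0.67 log units; beyond the scatter) and a 2.7-fold higher number from compound 1 to compound 4 (0.43 log units; beyond the scatter) lie modestly beyond the scatter, whereas compound 1 and compound 3 could not be ordered. Halogen exchange on this aromatic carbon, para to a large group, is therefore not always silent, and the outcome depends on which halogens are exchanged. The ethoxy group does not separate from fluoro, since a 1.8-fold higher number from compound 2 to compound 4 (0.24 log units; within the scatter) stays within the scatter, although compound 2 did separate from compound 3.

The compounds shown leave open whether an amine or a carboxylic acid at this place would stay within this narrow span of numbers. Nothing at hand bears on why the fluoro compound differs from the bromo and iodo compounds.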